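The source may report more compounds than this note shows. Statements on the series, on what has been measured and on what is new or still open speak of the compounds shown alone.

Compound 1 `Cc1noc(C)c1-c1cnc(N)c(Oc2ccc(C(=O)NC3CC3)cc2)n1` and compound 2 `Cc1noc(C)c1-c1cnc(N)c(Oc2ccc(C(=O)NC3CCCCC3)cc2)n1` share one core and differ only in the ring on the amide-type nitrogen. In a functional assay on U-87MG ATCC cells for inhibition, with U-87 MG (Homo sapiens) as the target, read by MTT assay, with a stated time of 72 h (a higher number here means a weaker inhibitor, a lower number a stronger inhibitor), compound 1 gives 43300 nM, and compound 2 gives 40400 nM. Compound 2 has the lowest of the two numbers, yet the step of a 1.1-fold lower number from compound 1 to compound 2 (0.03 log units; within the scatter) is too small to count as a real difference, so the two cannot be ranked. Compound 3 `Cc1noc(C)c1-c1cnc(N)c(Oc2ccc(C(=O)Nc3cccc(Cl)n3)cc2)n1` is the next step from compound 2: 6-chloropyridin-2-yl in place of cyclohexyl on an amide-type nitrogen. Among the compounds with values here, the only step measured so far, the one from compound 1 to compound 2, swapped one saturated ring for another at the same nitrogen and left the number essentially unchanged; it bears on the new step only as far as showing that this nitrogen accepts a change of ring. An aromatic ring with a chlorine is a different kind of group, so no direction can be read from it. Compound 3 is therefore expected to move by about a 1.2-fold lower number from compound 2 to compound 3 (0.06 log units; within the scatter), giving an estimate of 35000 nM with a range from 9000 nM to 130000 nM.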

Compound 3, half-maximal inhibitory concentration: 64100 nM
Compound 3: middle estimate off by 1.8-fold (0.26 log units), on the low side; low and high end bracket the measured number.
By their numbers in this assay, from the lowest: compounds 2, 1 and 3 (each within the scatter of the next).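

In this assay, the two new steps, a 1.6-fold higher number from compound 2 to compound 3 (0.20 log units; within the scatter) and a 1.5-fold higher number from compound 1 to compound 3 (0.17 log units; within the scatter), extend what the saturated rings suggested. The amide-type nitrogen also accepts 6-chloropyridin-2-yl, an aromatic ring with a hetero atom and a chlorine, without a step beyond the scatter. Cyclopropyl, cyclohexyl and 6-chloropyridin-2-yl therefore cannot be told apart at this position, even though the new group brings a hydrogen-bond acceptor that cyclohexyl lacks. Nothing at hand explains this flat picture.

As far as these compounds go, it remains open whether a group of another kind on this nitrogen, such as a plain methyl, a longer chain ending in an amine or a carboxylic acid, would give a step beyond the scatter. Phenyl or unsubstituted pyridin-2-yl would show whether the chlorine matters at all.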